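A Carboxy Group Replacing Trifluoromethyl on a Pyrazole Series

The compounds below may be only part of what the source reports. "The series", "measured", "known", "first", "only" and "open" are said of these compounds alone.

Measured so far:
compound 1, `Cc1n[nH]c(C(=O)O)c1Cc1ccc(C(F)(F)F)cc1`, 12%
compound 2, `Cc1n[nH]c(C(N)=O)c1Cc1cccc(-c2ccc(F)cc2)c1`, 14%

In an assay on isolated protein for inhibition of 2-Hydroxyacid oxidase 2 (Homo sapiens), tested at 10 uM (on this read-out higher numbers stand for a stronger effect at the one concentration tested and lower numbers for a weaker effect), compound 1 gives 12%, the lower of the two numbers, while compound 2 gives 14%; the gap between them lies within the scatter, so neither stands apart. Compound 3, `Cc1n[nH]c(C(=O)O)c1Cc1ccc(C(=O)O)cc1`, has not been measured. It differs from compound 1 by carboxy in place of trifluoromethyl on an aromatic carbon. For the measured compounds named here, no step between measured compounds is known, so the size of the effect is unknown; the expected step of no change at the digits printed from compound 1 to compound 3 (within the scatter) is small, perhaps none beyond the scatter. Compound 3 is therefore expected to give 12%, within 0% to 30%.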

Compound 3, a percentage reported as inhibition, at one concentration (the size of the read-out at that concentration, not a potency): 22%
Estimate against measurement, compound 3: 10 percentage points below; measured number inside the range.
By their numbers in this assay, from the lowest: compounds 1, 2 and 3 (each within the scatter of the next).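

In this assay, carboxy in place of trifluoromethyl on this aromatic carbon, para to a large group, gives a number 10 percentage points higher from compound 1 to compound 3 (within the scatter), so this first change at the position does not move the read-out clear of the usual variation. The position therefore accepts either group with no firm difference in this test, even though the two groups differ in their counted hydrogen-bond donors and acceptors. Nothing measured here offers an explanation for this result. On these data alone, whether an amine or a nitrile on the same carbon would produce a change beyond the scatter remains open.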